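A few compounds are considered here, and "the series" means these few. Any claim that something is new, unique, unknown or untested is made for them only; others in the source may bear on it.

Measured compounds in a functional assay on PC-3 cells (Homo sapiens) for antiproliferative activity, read by MTT assay, with a stated time of 24 h; a lower number here means a stronger inhibitor, a higher number a weaker inhibitor:
- compound 1, `CCn1c(C(=O)N[C@H](C)CO)ccc1C(CC)(CC)c1ccc(OCS(=O)(=O)c2ccccc2)c(C)c1`: 7790 nM
- compound 2, `CCn1c(C(=O)N[C@H](CO)C(C)C)ccc1C(CC)(CC)c1ccc(OCS(=O)(=O)c2ccccc2)c(C)c1`: 7300 nM

Compound 2 stands with compound 1 in this assay, the two values lying within the scatter of each other, so neither can be set above the other. Compound 3, `CCn1c(C(=O)N[C@H](CC(=O)O)C(=O)O)ccc1C(CC)(CC)c1ccc(OCS(=O)(=O)c2ccccc2)c(C)c1`, has not been measured. Its change from compound 2 is 1,2-dicarboxyethyl in place of 1-(hydroxymethyl)-2-methylpropyl on an amide-type nitrogen. Going by the values given here, the only step recorded at this position is a 1.1-fold lower number from compound 1 to compound 2 (0.03 log units; within the scatter), a swap of one hydroxymethyl-bearing chain for another that left the number unmoved. Among the compounds with values here, that step says little about the present change, which exchanges the hydroxymethyl-bearing chain for one bearing two carboxylic acids; no pair shows such an exchange. The expectation is therefore loosely held: compound 3 is expected to give a somewhat higher number, a step of a 1.8-fold higher number from compound 2 to compound 3 (0.25 log units; within the scatter), with wide uncertainty. For compound 3 the estimate in this assay is 13000 nM, in the range 4500 nM to 40000 nM.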

Compound 3, half-maximal inhibitory concentration: > 50000 nM
Compound 3: no number, only a limit (the forecaster's own chance of this, stated with the estimate: 15%); middle value at least 3.8-fold (0.58 log units) away from the limit.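

In this assay, the amide-type nitrogen tolerated the exchange of one hydroxymethyl-bearing chain for another, but it does not tolerate every change: 1,2-dicarboxyethyl gives an at least 6.8-fold higher number from compound 2 to compound 3 (0.83 log units; beyond the scatter), and an at least 6.4-fold higher number from compound 1 to compound 3 (0.80 log units; beyond the scatter). Compound 3 has only a limit, > 50000 nM, and not a number. Both steps therefore give only a minimum size, because the reading for compound 3 stops at a limit: the limit of > 50000 nM in this assay, at which 1 of the 3 values shown sits.

The compounds shown leave open whether a single carboxylic acid on this chain would be enough to produce such a step or whether both are needed, and whether the hydroxymethyl group matters at all. Going by these compounds, how a methyl ester of these acids, an amine or a longer chain bearing one carboxylic acid would read at this nitrogen also remains open.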